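The compounds below may be only part of what the source reports. "The series", "measured", "known", "first", "only" and "open" are said of these compounds alone.

Measured in a physicochemical assay for solubility, using the shake flask method, in simulated intestinal fluid, measured as kinetic solubility, with a stated time of 2 h, at 25 degrees C, at pH 6.5; on this read-out higher numbers stand for higher solubility and lower numbers for lower solubility:

- Compound 1 `Cc1noc(-c2nc(C)c3c(c2N)C(=O)N(Cc2ccc(Oc4ccc(F)cc4)cc2)C3=O)n1`: 23800 nM
- Compound 2 `Cc1noc(-c2nc(C)c3c(c2N)C(=O)N(CC2CCOCC2)C3=O)n1`: 5700 nM
- Compound 3 `Cc1noc(-c2nc(C)c3c(c2N)C(=O)N(Cc2cccc(F)c2)C3=O)n1`: < 5000 nM (a limit of the assay, not a number)

Compound 3 has no exact reading and stands at the limit of < 5000 nM in this assay, at which 1 of the 3 values shown sits.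

The next compound to consider is compound 4 `Cc1noc(-c2nc(C)c3c(c2N)C(=O)N(Cc2ccc(OC(F)F)cc2)C3=O)n1`. It keeps the core of compound 3 and differs only in the group on a saturated chain carbon bound to an amide-type nitrogen in a ring: 4-(difluoromethoxy)phenyl in place of 3-fluorophenyl on a saturated chain carbon bound to an amide-type nitrogen in a ring.

Among the compounds with values here, the one measured step at this place is an at least 1.1-fold lower number from compound 2 to compound 3 (0.05 log units; that floor lies within the scatter). As far as these compounds go, that step gives only a floor, so its true size remains open, and it offers no firm guide to the change now in question. Compound 1 carries a different aromatic group at the same place, and compound 1 gives 23800 nM.

No clear direction can be drawn from so few compounds, so no shift beyond the scatter is expected. The expected step is a number no lower from compound 3 to compound 4 (the limit leaves the size open). A result reported only as a limit would be no surprise. For compound 4 the estimated value is 5000 nM, with an expected range from 2000 nM to 15000 nM.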

Compound 4, solubility: < 5000 nM
Compound 4 ended at the assay's limit; the forecaster's own chance of this, stated with the estimate: 50%; the middle value sits exactly at the limit.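

In this assay compound 4 gives < 5000 nM, which is a limit of the assay and not a number, and compound 3 now shares that same limit: the limit of < 5000 nM in this assay, at which 2 of the 4 values shown sit.

Within the data shown here, putting difluoromethyl in place of 4-fluorophenyl on an oxygen on an aromatic ring gives an at least 4.7-fold lower number from compound 1 to compound 4 (0.67 log units; beyond the scatter), the first step at this place that is beyond the scatter, so a change in this group can shift the reading clearly. Against the oxan-4-yl group, the result is an at least 1.1-fold lower number from compound 2 to compound 4 (0.05 log units; that floor lies within the scatter), a floor that lies within the scatter, and the step between the two compounds at the limit cannot be read.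

As far as these compounds go, the true readings of compound 3 and compound 4 therefore stay open, and the two cannot be placed in order. Also open, from the compounds shown here alone, is what an amine or a carboxylic acid on the saturated chain carbon bound to an amide-type nitrogen in a ring would give, and whether either would return a number rather than a limit.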